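A few compounds are considered here, and "the series" means these few. Any claim that something is new, unique, unknown or untested is made for them only; others in the source may bear on it.

Compound 1 `O=C(/C=C\Nc1ccc(F)cc1)c1nc(-c2ccc(F)cc2)n2ccccc12`, compound 2 `COc1ccc(N/C=C\C(=O)c2nc(-c3ccc(C(F)(F)F)cc3)n3ccccc23)cc1OC` and the still unmeasured compound 3 `O=C(/C=C\Nc1ccc2cc[nH]c2c1)c1nc(-c2ccc(C(F)(F)F)cc2)n2ccccc12` share one core and differ in the group carried on the amine nitrogen. In a functional assay on BT-474 cells (Homo sapiens) for cytotoxicity, read by MTT assay, with a stated time of 48 h (on this read-out lower numbers stand for stronger inhibition and higher numbers for weaker inhibition), compound 1 gives 16900 nM. For compound 2 the reading is only a limit, > 30000 nM, so compound 2 sits at the limit of > 30000 nM in this assay, at which 1 of the 2 values shown sits, and no number is known for it. Going to compound 3 means (1H-indol-6-yl in place of 3,4-dimethoxyphenyl on an amine nitrogen). Among the measured compounds shown here, no measured step covers this change, so the step expected here is an at least 1.2-fold lower number from compound 2 to compound 3 (0.07 log units; that floor lies within the scatter), none beyond the usual scatter. Compound 3 is therefore estimated at 25000 nM in this assay, with a range from 8000 nM to 80000 nM.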

Compound 3, half-maximal inhibitory concentration: > 30000 nM
Compound 3 ended at the assay's limit; the forecaster's own chance of this, stated with the estimate: 45%; middle value at least 1.2-fold (0.07 log units) away from the limit.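

Compound 2 and compound 3 both end at a limit, not a number, so no step can be read between them: the limit of > 30000 nM in this assay, at which 2 of the 3 values shown sit. The compounds shown leave open whether 1H-indol-6-yl and 3,4-dimethoxyphenyl on an amine nitrogen differ at all on this read-out.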